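The source may hold more compounds than are shown below. What is called first, only, known or untested is meant among the compounds shown, and "the series" means these compounds.

Of the compounds shown here, two have been measured in a functional assay on KETR3 cells (Homo sapiens) for inhibition, read by MTT assay, with a stated time of 120 h; a higher number here means a weaker inhibitor, a lower number a stronger inhibitor. Compound 1, with the structure `CC(NC(=O)c1cccc(-c2ccc(NC(=O)Nc3ccc(Cl)c(C(F)(F)F)c3)cc2)c1)c1ccccc1`, carries the shared core joined to a phenyl ring that bears an amide; in this assay compound 1 gives 6460 nM. Compound 2, with the structure `CNC(=O)/C=C/c1ccc(NC(=O)Nc2ccc(Cl)c(C(F)(F)F)c2)cc1`, keeps the same core but replaces the phenyl ring with a short chain ending in a methylamide; in this assay compound 2 gives 21200 nM. Compound 2 thus stands at the highest number of the two, and its gap to compound 1, the nearest value, lies beyond the usual scatter of repeated measurements.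

Compound 3, with the structure `CNC(=O)c1cccc(-c2ccc(NC(=O)Nc3ccc(Cl)c(C(F)(F)F)c3)cc2)c1`, has not yet been measured. It differs from compound 2 in one place: 3-(methylcarbamoyl)phenyl in place of 2-(methylcarbamoyl)ethenyl on an aromatic carbon. Compound 3 therefore resembles compound 1 more closely than compound 2 does, with only the amide substituent on the outer ring changed. On that basis the number for compound 3 is expected to move downward from compound 2, with the estimated step being a 3.0-fold lower number from compound 2 to compound 3 (0.48 log units; beyond the scatter). The estimate for compound 3 in this assay is 7000 nM, with a range from 2500 nM to 20000 nM.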

Compound 3, half-maximal inhibitory concentration: 39300 nM
Estimate against measurement, compound 3: 5.6-fold (0.75 log units) below, and the stated range ends below it.
By their numbers in this assay, from the lowest: compound 1; then compounds 2 and 3 (each within the scatter of the next).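

In this assay, 3-(methylcarbamoyl)phenyl in place of 2-(methylcarbamoyl)ethenyl at this position, para to a large group, gives a 1.9-fold higher number from compound 2 to compound 3 (0.27 log units; within the scatter), so the two groups cannot be told apart here, and the added aromatic ring alone brings no measurable change. The substituent on the amide nitrogen, by contrast, does separate two compounds: methyl in place of 1-phenylethyl gives a 6.1-fold higher number from compound 1 to compound 3 (0.78 log units; beyond the scatter), which ties the lower number of compound 1 to its 1-phenylethyl group rather than to the outer aromatic ring alone. Nothing at hand explains why either step has the size it has.

The compounds shown leave open which part of the 1-phenylethyl group matters, and a benzyl group or a longer alkyl chain on the same amide nitrogen would help to separate the contribution of its phenyl ring from that of its branching methyl. They also leave open whether 1-phenylethyl on the amide of the ethenyl series would bring a similar step, and whether a carboxylic acid or an amine in place of the amide would change the number at all.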